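The compounds below may be only part of what the source reports. "The series", "measured", "known", "first", "only" and "open" are said of these compounds alone.

Measured so far in a functional assay on the whole organism (strain Wistar) for inhibition, with Rattus norvegicus as the target, read by paw edema, with stated times of 60 min and 3 h, at a dose of 100 mg/kg by the oral route; a higher number here means more inhibition at the dose given (going by the name of the read-out), a lower number less inhibition:

compound 1, `COc1cc2c(cc1OC)C(CC(=O)N(C)C)CC2`: 34.8%
compound 2, `COc1cc2c(cc1OC)C(CC(=O)NCc1ccccc1)CC2`: 14.5%
compound 3, `COc1cc2c(cc1OC)C(CC(=O)N1CCCCC1)CC2`: 31.9%

Compound 3 stands second highest of the three numbers. Its nearest neighbour is compound 1: a number 2.9 percentage points lower from compound 1 to compound 3 (within the scatter), so the two cannot be told apart. Its furthest neighbour is compound 2: a number 17.4 percentage points higher from compound 2 to compound 3 (beyond the scatter), a difference that does hold up. The only variable so far is the group on the carbonyl carbon; the benzylamino in compound 2 gave the one clear drop, a number 20.3 percentage points lower from compound 1 to compound 2 (beyond the scatter), while exchanging dimethylamino for piperidin-1-yl changed nothing resolvable.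

Compound 4, `COc1cc2c(cc1OC)C(CC(=O)N1CCOCC1)CC2`, is the next step from compound 3: morpholin-4-yl in place of piperidin-1-yl on a carbonyl carbon. Among the measured compounds shown here, no measured step covers this exact exchange. For the measured compounds named here, the steps that bear on it are those between the two acyclic and cyclic tertiary amides, compound 1 and compound 3, which stayed within the scatter, and the step to the secondary benzylamino in compound 2, which did not. Since compound 4 keeps a six-membered cyclic tertiary amide, the expected step of a number 3.9 percentage points lower from compound 3 to compound 4 (within the scatter) is small, with little confidence in its direction. Compound 4 is expected to give 28%, within 15% to 40%.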

Compound 4, a percentage reported as inhibition, in the whole organism at one dose (the size of the read-out at that dose, not a potency): 19.6%
Compound 4: middle estimate off by 8.4 percentage points, on the high side, and the stated range covers the measured number.
By their numbers in this assay, from the lowest: compounds 2 and 4 (each within the scatter of the next); then compounds 3 and 1 (each within the scatter of the next).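

In this assay, the group on the carbonyl carbon now separates two six-membered cyclic tertiary amides, a number 12.3 percentage points lower from compound 3 to compound 4 (beyond the scatter), so a tertiary amide alone does not keep the number at the level of compound 1 and compound 3; the exchange puts a ring oxygen, counted as the one hydrogen-bond acceptor of morpholin-4-yl, in place of a ring carbon. Morpholin-4-yl also falls short of the acyclic group, a number 15.2 percentage points lower from compound 1 to compound 4 (beyond the scatter), while against the secondary amide the reading is a number 5.1 percentage points higher from compound 2 to compound 4 (within the scatter), so compound 2 and compound 4 cannot be told apart and form a lower pair beneath compound 1 and compound 3, with compound 4 going against any split of secondary from tertiary amides. Nothing at hand bears on why this exchange lowers the number.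

Still open, as far as these compounds go, is whether the ring oxygen itself goes with the lower number, a question that piperazin-1-yl or 4-methylpiperazin-1-yl on the same carbonyl carbon would put to the test. Also open, from the compounds shown here alone, is how a smaller ring such as pyrrolidin-1-yl, or a carboxylic acid in place of the amide, would read on the shared core.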